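The source may report more compounds than this note shows. Statements on the series, on what has been measured and on what is new or still open speak of the compounds shown alone.

Values measured so far in a functional assay on the whole organism for antagonist activity, with Mus musculus as the target; a lower number here means that less compound is needed, a higher number that more compound is needed for the effect

- Compound 1 `CCC(=O)N(c1ccc(Cl)c(Cl)c1)C1CCCC1O` gives 9 mg/kg
- Compound 2 `CCC(=O)N(c1cccc(C(F)(F)F)c1)C1CCCC1N(C)C` gives 0.2 mg/kg
- Compound 3 `C=CCNC1CCCC1N(C(=O)CC)c1ccc(Cl)c(Cl)c1` gives 3 mg/kg

Of these three numbers, compound 3 at 3 mg/kg is the middle one, with compound 1 higher and compound 2 lower. Compound 4 `C=CCN(C)C1CCCC1N(C(=O)CC)c1ccc(Cl)c(Cl)c1` is compound 3 with methyl in place of hydrogen on an amine nitrogen, the whole difference being methyl in place of hydrogen on an amine nitrogen and nothing else.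

For the measured compounds named here, no measured step isolates this change. The nearest evidence is a 3.0-fold lower number from compound 1 to compound 3 (0.48 log units; beyond the scatter) when allylamino replaces hydroxy on a saturated ring carbon. That step shows the number can move with the group at this place, but it is a different change and gives no direct size for adding a methyl. Compound 2 at 0.2 mg/kg also has no hydrogen on its amine nitrogen, carrying two methyl groups there. It differs from compound 3 elsewhere too, however, so its low number cannot be credited to that feature alone.

A modest move toward a lower number in this assay is therefore expected. The estimated step is a 2.5-fold lower number from compound 3 to compound 4 (0.40 log units; beyond the scatter) and could turn out smaller. For compound 4 the estimate is 1.2 mg/kg with an expected range from 0.3 mg/kg to 4 mg/kg in this measurement.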

Compound 4, dose for half-maximal effect: 0.2 mg/kg
Compound 4: middle estimate off by 6.0-fold (0.78 log units), on the high side; the whole stated range lies above it.
By their numbers in this assay, from the lowest: compounds 2 and 4 (each within the scatter of the next); then compound 3; then compound 1.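

In this assay, putting methyl in place of hydrogen on the amine nitrogen gives a 15-fold lower number from compound 3 to compound 4 (1.18 log units; beyond the scatter) and shows that this nitrogen is a highly sensitive place, even for a very small change. Replacing hydroxy with the full allyl(methyl)amino group gives a 45-fold lower number from compound 1 to compound 4 (1.65 log units; beyond the scatter) on the same core, and most of that distance lies in the methyl step rather than in the earlier change to allylamino, which gave only a 3.0-fold lower number from compound 1 to compound 3 (0.48 log units; beyond the scatter) on its own. The hydrogen on this nitrogen therefore matters to the number far more than the first two related compounds could reveal. For the compounds shown here, nothing available here explains why so small an addition moves the number so far.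

As far as these compounds go, what an ethyl group or a longer chain would do on this nitrogen in place of methyl remains open. Also open, from the compounds shown here alone, is whether the allyl group matters at all: a dimethylamino group on the core of compound 4 would test this, since compound 2 carries dimethylamino but differs elsewhere as well.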